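Swapping a Methoxyphenyl Amide for a Nitrophenyl Amide

The compounds below may be only part of what the source reports. "The series", "measured", "known", "first", "only" and "open" are said of these compounds alone.

Compound 1 `O=C(CSc1nc(Nc2ccccc2)c2ccccc2n1)Nc1cccc(F)c1` — 6790 nM
Compound 2 `O=C(CSc1nc(Nc2ccccc2)c2ccccc2n1)Nc1cccc(Cl)c1` — 8460 nM
Compound 3 `COc1cccc(NC(=O)CSc2nc(Nc3ccccc3)c3ccccc3n2)c1` — 19400 nM

In a functional assay on NCI-H1975 cells (Homo sapiens) for inhibition, read by MTT assay, with a stated time of 72 h (on this read-out higher numbers stand for weaker inhibition and lower numbers for stronger inhibition), compound 3 gives the highest number of the three measured compounds. The steps of a 2.9-fold higher number from compound 1 to compound 3 (0.46 log units; beyond the scatter) and a 2.3-fold higher number from compound 2 to compound 3 (0.36 log units; beyond the scatter) both run upward, while a 1.2-fold higher number from compound 1 to compound 2 (0.10 log units; within the scatter) is too small to read. Compound 4 `O=C(CSc1nc(Nc2ccccc2)c2ccccc2n1)Nc1ccc([N+](=O)[O-])cc1` differs from compound 3 by 4-nitrophenyl in place of 3-methoxyphenyl on an amide-type nitrogen. For the measured compounds named here, no measured step involves a nitro group or a shift around the ring, so none of the three steps bears directly on this change; they only show that the group on this ring can move the number by a modest amount. The step of a 1.8-fold lower number from compound 3 to compound 4 (0.25 log units; within the scatter) is therefore expected to be small and of uncertain direction. Compound 4 is estimated at 11000 nM, within 4000 nM to 30000 nM.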

Compound 4, half-maximal inhibitory concentration: 13000 nM
For compound 4 the middle estimate is 1.2-fold (0.07 log units) below the measured one; measured number inside the range.
By their numbers in this assay, from the lowest: compounds 1, 2, 4 and 3 (each within the scatter of the next, the first and the last beyond it).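

In this assay, the 4-nitrophenyl amide cannot be told apart from any of the three earlier amides: a 1.5-fold lower number from compound 3 to compound 4 (0.17 log units; within the scatter), a 1.5-fold higher number from compound 2 to compound 4 (0.19 log units; within the scatter) and a 1.9-fold higher number from compound 1 to compound 4 (0.28 log units; within the scatter). A nitro group is therefore tolerated here without a readable change, although this single swap alters both the group and its printed ring number, so the two changes cannot be separated. Nothing measured here accounts for this result. Still open, on these data alone, is how the methoxy and nitro groups would compare at the same ring number. An amine or a carboxylic acid on this ring also remains untested in the compounds shown.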